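Replacing the pentylamino group of compound 3

A few compounds are considered here, and "the series" means these few. Any claim that something is new, unique, unknown or untested is made for them only; others in the source may bear on it.

Compound 1, `Cc1ccc(Cn2c(O)nc3c(N)ncnc32)cc1`: 10 uM
Compound 2, `COc1nc2c(N)ncnc2n1Cc1ccccc1`: > 10 uM (a limit of the assay, not a number)
Compound 3, `CCCCCNc1nc(N)c2nc(O)n(Cc3ccccc3)c2n1`: 0.1 uM

In a functional assay (spleen, spleen) for activation, with Mus musculus as the target (on this read-out higher numbers stand for an effect only at larger amounts of compound and lower numbers for an effect already at smaller amounts), compound 3 gives 0.1 uM, the lowest of the two numbers. The nearest number, that of compound 1, lies higher by a gap beyond the usual scatter. For compound 2 only a limit is known, (the limit of > 10 uM in this assay, at which 1 of the 3 values shown sits).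

Compound 4, `CCCC[S+]([O-])c1nc(N)c2nc(O)n(Cc3ccccc3)c2n1`, has not been measured. It differs from compound 3 in one place: a group of 6 heavy atoms (4 carbon, 1 oxygen, 1 sulfur; no ring) in place of a group of 6 heavy atoms (5 carbon, 1 nitrogen; no ring), on an aromatic carbon. Within the data shown here, no measured step covers such an exchange, so only an expectation can be given. In this assay the step is expected to go toward higher numbers, as a 10-fold higher number from compound 3 to compound 4 (1.00 log units; beyond the scatter). Compound 4 is therefore estimated at 1 uM, within 0.1 uM to 10 uM.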

Compound 4, minimum effective concentration: 0.01 uM
Compound 4: the middle estimate sits 100-fold (2.00 log units) above what was measured; measured number outside the range, below it.
By their numbers in this assay, from the lowest: compound 4; then compound 3; then compound 1.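

In this assay, exchanging pentylamino for the butyl chain on an oxidised sulfur gives a 10-fold lower number from compound 3 to compound 4 (1.00 log units; beyond the scatter) on this aromatic carbon between two ring nitrogen atoms. The position therefore keeps a low number without a hydrogen-bond donor on the attached group, and it accepts a link other than nitrogen. Nothing given here accounts for the gain. On these data alone, what stays open is how much of it belongs to the oxygen on sulfur, which a plain butylthio group or a sulfone would separate. A butylamino group would likewise separate chain length from the linking atom.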